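The source may hold more compounds than are shown below. What is called first, only, known or untested is meant among the compounds shown, and "the series" means these compounds.

In an assay on isolated protein for inhibition of methionine--tRNA ligase, cytoplasmic (Homo sapiens) (on this read-out higher numbers stand for weaker inhibition and lower numbers for stronger inhibition), compound 2 `O=C(O)c1cc(-c2ccc(-c3ccc(F)cc3)cc2)n(-c2ccc(Cl)cc2Cl)n1` gives 41300 nM, the highest of the two numbers shown. Its nearest neighbour, compound 1 `O=C(O)c1cc(-c2ccc(-c3ccc(Cl)cc3Cl)cc2)n(-c2ccc(Cl)cc2Cl)n1`, gives 11900 nM in this assay. The step of a 3.5-fold higher number from compound 1 to compound 2 (0.54 log units; beyond the scatter) lies beyond the scatter. Compound 3 `O=C(O)c1cc(-c2ccc(-c3ccc(Cl)cc3Cl)cc2)n(Cc2cccnc2)n1` reports only a limit in this assay, > 100000 nM. The step of an at least 8.4-fold higher number from compound 1 to compound 3 (0.92 log units; beyond the scatter) is read against that limit (the limit of > 100000 nM in this assay, at which 1 of the 3 values shown sits). Compound 4 `O=C(O)c1cccc(-c2ccc(-c3cc(C(=O)O)nn3-c3ccc(Cl)cc3Cl)cc2)c1` differs from compound 2 by 3-carboxyphenyl in place of 4-fluorophenyl on an aromatic carbon. Among the compounds with values here, of the measured steps, only a 3.5-fold higher number from compound 1 to compound 2 (0.54 log units; beyond the scatter) changes the same ring, and no measured step introduces a 3-carboxyphenyl, so the expectation rests on that single change and carries wide uncertainty. For compound 4 a step of a 1.4-fold lower number from compound 2 to compound 4 (0.14 log units; within the scatter) is expected. Compound 4 is estimated at 30000 nM, between 7000 nM and 130000 nM.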

Compound 4, half-maximal inhibitory concentration: 40900 nM
Compound 4: middle estimate off by 1.4-fold (0.13 log units), on the low side, within the range that was stated.
By their numbers in this assay, from the lowest: compound 1; then compounds 4 and 2 (each within the scatter of the next). At a limit, above all of these: compound 3.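

In this assay the step of a 1.0-fold lower number from compound 2 to compound 4 (0.00 log units; within the scatter) shows that 3-carboxyphenyl and 4-fluorophenyl are not told apart at this position, although only 3-carboxyphenyl carries a hydrogen-bond donor. With a 3.4-fold higher number from compound 1 to compound 4 (0.54 log units; beyond the scatter) beside a 3.5-fold higher number from compound 1 to compound 2 (0.54 log units; beyond the scatter), both groups read apart from 2,4-dichlorophenyl on the same carbon. Nothing measured here accounts for this. On these data alone, it remains open whether an amine or an amide in place of the carboxylic acid of 3-carboxyphenyl would read the same, and whether chlorine on that ring alone separates these compounds.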